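From methoxy to isopropoxy on compound 2

The compounds below may be only part of what the source reports. "The series", "measured", "known", "first", "only" and "open" are said of these compounds alone.

Two compounds have been measured in a functional assay on NCI-H460 cells (Homo sapiens) for cytotoxicity, read by MTT assay, with a stated time of 96 h (on this read-out lower numbers stand for stronger inhibition and higher numbers for weaker inhibition), so far:

- compound 1 `COc1ncc(-c2cc3c(C)nc(N)nc3n([C@H]3CC[C@H](OCCO)CC3)c2=O)cc1NS(=O)(=O)c1ccc(F)cc1F` gives 360 nM
- compound 2 `COc1ncc(-c2cc(OC)c3nc(N)nc(C)c3c2)cc1NS(=O)(=O)c1ccc(F)cc1F` gives 280 nM

These two values lie within the usual scatter of each other, so compound 2 cannot be told apart from compound 1 on these numbers. Compound 3 `COc1ncc(-c2cc(OC(C)C)c3nc(N)nc(C)c3c2)cc1NS(=O)(=O)c1ccc(F)cc1F` differs from compound 2 by isopropyl in place of methyl on an oxygen on an aromatic ring and is not yet measured. Among the measured compounds shown here, no measured pair shows this change, so only a modest step of a 1.4-fold higher number from compound 2 to compound 3 (0.13 log units; within the scatter) is expected, towards weaker inhibition, and it may stay within the scatter. The estimated value for compound 3 is 380 nM with an expected range from 130 nM to 1100 nM at this stage.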

Compound 3, half-maximal inhibitory concentration: 140 nM
Compound 3: the middle estimate sits 2.7-fold (0.43 log units) above what was measured; the range from low to high includes it.
By their numbers in this assay, from the lowest: compounds 3, 2 and 1 (each within the scatter of the next, the first and the last beyond it).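

In this assay, putting isopropyl in place of methyl on an oxygen on an aromatic ring gives a 2.0-fold lower number from compound 2 to compound 3 (0.30 log units; within the scatter), so compound 2 and compound 3 cannot be told apart. This one pair shows that the position takes isopropyl as well as methoxy's methyl, with no sign of a penalty. Nothing available here offers an explanation for this result.

Still open, going by these compounds, is whether a longer chain on this oxygen, or one ending in an amine or a carboxylic acid, would fit as well. Also open, on these data alone, is whether any group here can move the number beyond the scatter.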